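A few compounds are considered here, and "the series" means these few. Any claim that something is new, unique, unknown or untested is made for them only; others in the source may bear on it.

Compound 1 `CCCCCCCCCCCCC/C=C/[C@@H](O)[C@H](CO)n1cc(CCCCCC)nn1` gives 8200 nM in a functional assay on K562 cells (Homo sapiens) for cytotoxicity, read by MTT assay; a higher number here means that more compound is needed for the effect, a lower number that less compound is needed. Compound 2 `CCCCCCCCCCCCC/C=C/[C@@H](O)[C@H](CO)n1cc(CCCCCCCCCCCCC)nn1` reaches only a limit, > 50000 nM, in this assay.

Compound 2 therefore stands at the edge of what this assay can report, the one of the two measured values to sit there (the limit of > 50000 nM in this assay, at which 1 of the 2 values shown sits). Compound 3 `CCCCCCCCCCCCC/C=C/[C@@H](O)[C@H](CO)n1cc(CCCC)nn1` differs from compound 2 by hydrogen in place of nonyl on a saturated chain carbon, four bonds along the chain from an aromatic carbon. For the measured compounds named here, the one measured step that bears on this change is an at least 6.0-fold higher number from compound 1 to compound 2 (0.78 log units; beyond the scatter), where the longer chain brought the higher number; compound 3 runs that change the other way and further, so a lower number is expected for compound 3, an at least 8.3-fold lower number from compound 2 to compound 3 (0.92 log units; beyond the scatter). Compound 3 is thus estimated at 6000 nM, with a range from 2000 nM to 20000 nM.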

Compound 3, half-maximal effective concentration: 12300 nM
The estimate for compound 3 lay 2.1-fold (0.31 log units) below the measured number; measured number inside the range.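

Hydrogen in place of nonyl gives an at least 4.0-fold lower number from compound 2 to compound 3 (0.60 log units; beyond the scatter), so the steep rise seen with the longest chain also holds in the shortening direction. Hydrogen in place of ethyl at the same place gives a 1.5-fold higher number from compound 1 to compound 3 (0.18 log units; within the scatter), so the two shorter chains are not separated in this assay, and only compound 2 stands apart. The value of compound 2 is a limit and not a number: the limit of > 50000 nM in this assay, at which 1 of the 3 values shown sits.

The compounds shown leave open at what chain length between those of compound 1 and compound 2 the number starts to rise. They also leave open what an amine or a carboxylic acid in place of the chain would give.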